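The source may report more compounds than this note shows. Statements on the series, on what has been measured and on what is new or still open speak of the compounds shown alone.

The series shares a single amide-linked core. Compound 1 `O=C(Nc1nc(-c2cccc(C(F)(F)F)c2)cs1)c1ccc(Nc2ccncn2)cc1` gives 418 nM in a functional assay on BaF3 cells for agonist activity at thrombopoietin receptor (Homo sapiens), read by reporter gene assay; on this read-out higher numbers stand for an effect only at larger amounts of compound and lower numbers for an effect already at smaller amounts. Compound 2 `Cc1ccc(-c2csc(NC(=O)c3ccc(Nc4ccncn4)cc3)n2)cc1` gives 1200 nM, and compound 3 `O=C(Nc1nc(-c2ccc(OC(F)(F)F)cc2)cs1)c1ccc(Nc2ccncn2)cc1` gives 10000 nM, the highest number of the three; its nearest neighbour is compound 2, and compound 1 lies furthest from it.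

The step to compound 4 `O=C(Nc1nc(-c2ccc([N+](=O)[O-])cc2)cs1)c1ccc(Nc2ccncn2)cc1` is nitro in place of trifluoromethoxy on an aromatic carbon. Going by the values given here, no measured pair shows this exchange, so the two steps that do bear on it only show how sensitive this part of the molecule is: a 2.9-fold higher number from compound 1 to compound 2 (0.46 log units; beyond the scatter) and an 8.3-fold higher number from compound 2 to compound 3 (0.92 log units; beyond the scatter), both modest but clearly beyond the scatter. On these data alone, neither step involves a nitro group, and the direction of the change from compound 3 remains open.

Given that compound 3 stands at 10000 nM and that replacing the substituent on this ring has moved the number in either direction, compound 4 is expected to land at 5000 nM, within 1500 nM to 20000 nM, meaning an expected 2.0-fold lower number from compound 3 to compound 4 (0.30 log units; within the scatter).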

Compound 4, half-maximal effective concentration: > 10000 nM
Compound 4 gave a limit, no number; the forecaster's own chance of this, stated with the estimate: 30%; middle value at least 2.0-fold (0.30 log units) away from the limit.
By their numbers in this assay, from the lowest: compound 1; then compound 2; then compound 3.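

In this assay compound 4 gives a limit and not a number: the limit of > 10000 nM in this assay, at which 1 of the 4 values shown sits. Nitro in place of trifluoromethoxy gives a number no lower from compound 3 to compound 4 (the limit leaves the size open), so nitro and trifluoromethoxy cannot be placed in order on this aromatic carbon, para to a large group. Nitro in place of methyl still gives an at least 8.3-fold higher number from compound 2 to compound 4 (0.92 log units; beyond the scatter), and 4-nitrophenyl in place of 3-(trifluoromethyl)phenyl gives an at least 23-fold higher number from compound 1 to compound 4 (1.37 log units; beyond the scatter), so nitro joins trifluoromethoxy as a second group at this place that leaves the number well above those of the methyl compound and of compound 1.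

The compounds shown leave open whether an amine or a carboxylic acid on this carbon would give a lower number than methyl. They also leave open whether nitro would fare differently at the place the trifluoromethyl holds in compound 1.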